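Swapping a furan for a pyridine on an enone tail

The source may hold more compounds than are shown below. What is called first, only, known or untested is meant among the compounds shown, and "the series" means these compounds.

Compound 1 `COc1ccc(C(=O)/C=C/c2ccc(F)cc2)c2c1C=CC(C)(C)O2` in a functional assay on HCT-116 cells (Homo sapiens) for antiproliferative activity, read by MTT assay, with a stated time of 24 h (on this read-out higher numbers stand for weaker inhibition and lower numbers for stronger inhibition), gives > 10000 nM, a limit of the assay.
Compound 2 `COc1ccc(C(=O)/C=C/c2ccsc2)c2c1C=CC(C)(C)O2` in this assay gives > 10000 nM, also a limit.
Compound 3 `COc1ccc(C(=O)/C=C/c2ccco2)c2c1C=CC(C)(C)O2` in this assay gives > 10000 nM, again a limit.

Compound 3 therefore sits at the limit, as do the other two values. The steps a step that the two limits leave unreadable from compound 1 to compound 2, a step that the two limits leave unreadable from compound 1 to compound 3 and a step that the two limits leave unreadable from compound 2 to compound 3 cannot be sized, since all three values sit at the limit of > 10000 nM in this assay, at which 3 of the 3 values shown sit. Compound 4 `COc1ccc(C(=O)/C=C/c2ccccn2)c2c1C=CC(C)(C)O2` differs from compound 3 by pyridin-2-yl in place of furan-2-yl on a double-bonded chain carbon bound to a double-bonded chain carbon. With every measured step unreadable, the expected step that the limit leaves unreadable from compound 3 to compound 4 is only an estimate with no set direction. Compound 4 is expected to give 15000 nM (range 4000 nM to 60000 nM), most likely again a limit.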

Compound 4, half-maximal inhibitory concentration: 6630 nM
Compound 4: middle estimate off by 2.3-fold (0.35 log units), on the high side; the measured number falls inside the stated range.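

In this assay, pyridin-2-yl is the only one of the four groups shown at this place, on a double-bonded chain carbon bound to a double-bonded chain carbon, that gives a number rather than a limit: the limit of > 10000 nM in this assay, at which 3 of the 4 values shown sit.

Against the three limits, the change reads as an at least 1.5-fold lower number from compound 3 to compound 4 (0.17 log units; that floor lies within the scatter), an at least 1.5-fold lower number from compound 2 to compound 4 (0.17 log units; that floor lies within the scatter) and an at least 1.5-fold lower number from compound 1 to compound 4 (0.17 log units; that floor lies within the scatter). Each of these is only a floor, so the real gaps could be larger or could stay within the scatter, and the steps among compound 1, compound 2 and compound 3 cannot be read.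

From the compounds shown here alone, whether pyridin-3-yl, pyridin-4-yl or plain phenyl would also give a number here remains open.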